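Pyrimidine regioisomer on the cyclopropane of the series

The compounds below may be only part of what the source reports. "The series", "measured", "known", "first", "only" and "open" are said of these compounds alone.

Compound 1 `CC[C@H](C)[C@H](N)CN(C(=O)[C@@H]1C[C@H]1c1ccccc1Cl)c1ccc(-c2ccccc2)cc1` and compound 2 `CC[C@H](C)[C@H](N)CN(C(=O)[C@@H]1C[C@H]1c1ncccn1)c1ccc(-c2ccccc2)cc1` share the core and differ only in the group on the saturated ring carbon. In a functional assay for agonist activity at G protein-coupled receptor 88 (Homo sapiens), read by HTRF and cAMP accumulation (on this read-out lower numbers stand for an effect already at smaller amounts and higher numbers for an effect only at larger amounts of compound), compound 1 gives > 25000 nM, which is a limit of the assay and not a number. In this assay, for the measured compounds named here, compound 2 gives 130 nM, the only number so far measured. Compound 1 sits at the limit (the limit of > 25000 nM in this assay, at which 1 of the 2 values shown sits). Going by the values given here, the single measured step is an at least 190-fold lower number from compound 1 to compound 2 (2.28 log units; beyond the scatter), showing that the aromatic group on the cyclopropane moves the read-out strongly.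

Compound 3 `CC[C@H](C)[C@H](N)CN(C(=O)[C@@H]1C[C@H]1c1cncnc1)c1ccc(-c2ccccc2)cc1` carries the change (pyrimidin-5-yl in place of pyrimidin-2-yl on a saturated ring carbon). Among the compounds with values here, no measured pair compares two pyrimidinyl isomers, so the step from compound 1 to compound 2 is the only one that bears on it; it shows that the identity of this aromatic group matters greatly, and the shift of both nitrogens away from the attachment carbon is expected to give back some of that gain. For compound 3 the expected step is a 5.4-fold higher number from compound 2 to compound 3 (0.73 log units; beyond the scatter), a weaker effect beyond the scatter. The estimate for compound 3 in this assay is 700 nM, within 120 nM to 8000 nM.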

Compound 3, half-maximal effective concentration: 19000 nM
Compound 3: middle estimate off by 27-fold (1.43 log units), on the low side; measured number outside the range, above it.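

Notes on the position: the gain seen for compound 2 does not belong to a pyrimidine ring as such. Same atoms, joined differently, give a 150-fold higher number from compound 2 to compound 3 (2.16 log units; beyond the scatter) in this assay and so the ring attachment on this saturated ring carbon decides the read-out, with pyrimidin-2-yl the only group shown here that reaches the low end of the range. Pyrimidin-5-yl recovers almost nothing relative to 2-chlorophenyl, since the comparison reads an at least 1.3-fold lower number from compound 1 to compound 3 (0.11 log units; that floor lies within the scatter) and gives no demonstrated gain, so compound 3 sits much nearer to compound 1 than to compound 2 on this read-out. Compound 1 still stands as a limit of the assay and not a number: the limit of > 25000 nM in this assay, at which 1 of the 3 values shown sits.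

Open, from the compounds shown here alone, is how pyrimidin-4-yl, pyridin-2-yl or pyridin-3-yl would read on this saturated ring carbon, which would show whether the result follows one particular ring nitrogen or needs both in the pyrimidin-2-yl arrangement. Also open, going by these compounds, is why the two pyrimidine isomers part so widely, as the values give no reason for it, and whether the same gap would hold on the opposite enantiomer of the cyclopropane.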